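A few compounds are considered here, and "the series" means these few. Any claim that something is new, unique, unknown or untested is made for them only; others in the source may bear on it.

Measured so far in a functional assay on HL-60 cells (Homo sapiens) for inhibition, read by MTT assay, with a stated time of 72 h; a higher number here means a weaker inhibitor, a lower number a stronger inhibitor
compound 1 `Cc1nc(-c2ccc(Cl)cc2)c(C(=O)N2CCN(c3cccc(C(=O)C(C)C)c3)CC2)o1` gives "not active" (no number reported)
compound 2 `Cc1nc(-c2ccccc2)c(C(=O)N2CCN(c3cccc(C(N)=O)c3)CC2)o1` gives 71 nM
compound 3 `CC(=O)c1ccc(N2CCN(C(=O)c3oc(C)nc3-c3ccccc3)CC2)cc1` gives "not active" (no number reported)

Compound 3 has no single number and is reported in this assay as ("not active" (no number reported)). Compound 1 shares that result ("not active" (no number reported)). Of the three, only compound 2 yields a number (71 nM), so compound 3 sits with the compounds that give no measurable potency.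

The next compound to be tested is compound 4 `COc1cccc(N2CCN(C(=O)c3oc(C)nc3-c3ccccc3)CC2)c1`, which keeps the shared core. The change (3-methoxyphenyl in place of 4-acetylphenyl on an amine nitrogen in a ring) puts 3-methoxyphenyl in place of 4-acetylphenyl on an amine nitrogen in a ring.

Within the data shown here, with no number for compound 3, the size of this step cannot be worked out, and no measured step between these compounds offers a guide. Compound 2 (71 nM) shows that a number is possible on this core, but one active compound is thin evidence. The expected direction in this assay is a modest gain at best, from no number to a fairly weak value, and another result without a number would be no surprise. For compound 4 the estimated value is 1000 nM, with an expected range from 100 nM to 10000 nM, should a number be reported at all.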

Compound 4, half-maximal inhibitory concentration: 34.8 nM
The estimate for compound 4 lay 29-fold (1.46 log units) above the measured number; the measured number lies below the stated range.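

In this assay, 3-methoxyphenyl in place of 4-acetylphenyl on the amine nitrogen of the six-membered ring separates compound 3, which has no number, from compound 4 at 34.8 nM, though the size of this step cannot be read. Methoxy in place of carbamoyl on an aromatic carbon gives a 2.0-fold lower number from compound 2 to compound 4 (0.31 log units; beyond the scatter), a modest change just beyond the usual scatter, so a measurable potency on this core does not depend on the carbamoyl group of the one earlier compound with a number. Nothing measured here explains why the 3-methoxyphenyl compound gives a number while the 4-acetylphenyl compound does not.

The step from compound 3 to compound 4 changes both the group and where it sits on the phenyl ring, so the two effects cannot be told apart; a 3-acetylphenyl or a 4-methoxyphenyl group would separate them. As far as these compounds go, whether an amine or a carboxylic acid in place of the methoxy group would still give a number also remains open.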